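This account rests on a few compounds, and the source may have more. Where it says the series, first, only, none or still open, it means among the compounds named here.

Working notes on a series sharing one core. Compound 1 `Nc1ccc2nc(N)sc2c1` is the smallest member shown. In a functional assay on the whole organism with Rattus norvegicus as the target (a higher number here means that more compound is needed for the effect, a lower number that less compound is needed), compound 1 gives > 10 mg/kg, which is a limit of the assay and not a number. Compound 2 `CCCCCCc1ccc2nc(N)sc2c1` carries a hexyl group on the core. In this assay, among the measured compounds shown here, compound 2 gives 7 mg/kg, the only reading that returns a number. Compound 3 `N=c1sc2cc(OC(F)(F)F)ccc2n1Cc1ccccc1` is the direct parent of the compound under consideration. In this assay compound 3 gives > 10 mg/kg, again a limit and not a number. Going by these compounds, compound 3 thus stands at the limit of > 10 mg/kg in this assay, at which 2 of the 3 values shown sit, so its true position is unknown beyond that limit.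

Compound 4 `C[S+]([O-])CCn1c(=N)sc2cc(OC(F)(F)F)ccc21` has not yet been measured in this assay. It differs from compound 3 by a group of 4 heavy atoms (2 carbon, 1 oxygen, 1 sulfur; no ring) in place of a group of 6 heavy atoms (6 carbon; one six-membered aromatic ring of carbon only), on a saturated chain carbon bound to an aromatic nitrogen. No pair of measured compounds differs in one place, so nothing is known about the size of any single change in this series, and the change at the saturated chain carbon bound to an aromatic nitrogen has no precedent among the compounds shown. Because compound 3 sits at the limit of > 10 mg/kg in this assay, at which 2 of the 3 values shown sit, a result at the limit again is the most likely outcome. The step is estimated at a step that the limit leaves unreadable from compound 3 to compound 4, no change beyond the scatter. Compound 4 is expected to give 15 mg/kg in this assay, within a range from 5 mg/kg to 50 mg/kg.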

Compound 4, dose for half-maximal effect: 1.1 mg/kg
For compound 4 the middle estimate is 14-fold (1.13 log units) above the measured one, outside the stated range (below it).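

In this assay, replacing the phenyl with the ring-free group of 4 heavy atoms (2 carbon, 1 oxygen, 1 sulfur), on a saturated chain carbon bound to an aromatic nitrogen, gives an at least 9.0-fold lower number from compound 3 to compound 4 (0.95 log units; beyond the scatter). Among the compounds shown here, this is the first readable step, and it shows that the phenyl is not needed at this place for a numerical reading, with compound 4 at 1.1 mg/kg. Going by these compounds, the true size of the change remains unknown beyond a lower bound, because compound 3 gives only a limit of the assay and not a number: the limit of > 10 mg/kg in this assay, at which 2 of the 4 values shown sit.

The compounds shown do not separate the loss of the phenyl from the arrival of the sulfur and oxygen, and a plain propyl chain, a thioether or a sulfone at the same place would be needed to tell these apart. On these data alone, it also remains open whether the change holds on the shared core when a chlorine or a methoxy group stands in place of the trifluoromethoxy group of compound 3 and compound 4.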